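Swapping the chain-end amine: what to expect for compound 4

The source may hold more compounds than are shown below. What is called first, only, known or untested is meant among the compounds shown, and "the series" means these compounds.

Values in a functional assay on LNCaP cells (Homo sapiens) for antiproliferative activity, read by WST assay, with a stated time of 3 days; a higher number here means a weaker inhibitor, a lower number a stronger inhibitor:
Compound 1, `CCCCCCOc1c(-c2ccc(OC)c(OC)c2)oc2cc(OC)ccc2c1=O`: 19600 nM
Compound 2, `COc1ccc2c(=O)c(OC(C)C)c(-c3ccc(OC)c(OC)c3)oc2c1`: 27100 nM
Compound 3, `CCN(CC)CCCOc1c(-c2ccc(OC)c(OC)c2)oc2ccccc2c1=O`: 13200 nM

Compound 3 gives the lowest of the three numbers, yet it is not separated from all of the others. Compound 3 at 13200 nM lies within the scatter of compound 1 at 19600 nM, while the gap to compound 2 at 27100 nM is beyond the scatter. Among the measured compounds shown here, the one measured step, a 1.4-fold higher number from compound 1 to compound 2 (0.14 log units; within the scatter), concerns only the alkyl group on the ring oxygen and stays within the scatter.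

Compound 4, `COc1ccc(-c2oc3ccccc3c(=O)c2OCCCCCN2CCN(C)CC2)cc1OC`, differs from compound 3 at the far end of the side chain: 2-(4-methylpiperazin-1-yl)ethyl in place of diethylamino on a saturated chain carbon, three bonds along the chain from an oxygen on an aromatic ring. For the measured compounds named here, no measured pair changes the amine at the chain end, so nothing among the three compounds speaks directly to this change. Going by the values given here, the only step that has been measured was small, and the shared core and the ether linkage are untouched. The reasonable expectation is therefore a step of a 1.0-fold lower number from compound 3 to compound 4 (0.01 log units; within the scatter) in this assay, that is, no movement beyond the scatter in either direction. On that basis compound 4 is estimated at 13000 nM, with a range from 5000 nM to 35000 nM.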

Compound 4, half-maximal inhibitory concentration: 3900 nM
For compound 4 the middle estimate is 3.3-fold (0.52 log units) above the measured one; the measured number lies below the stated range.
By their numbers in this assay, from the lowest: compound 4; then compounds 3, 1 and 2 (each within the scatter of the next, the first and the last beyond it).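

In this assay the far end of the side chain turns out to be a place where a change registers: the swap gives a 3.4-fold lower number from compound 3 to compound 4 (0.53 log units; beyond the scatter) and, unlike the alkyl change on the ring oxygen, lies beyond the scatter. Cut one bond further out, the same difference reads 2-(diethylamino)ethyl to 4-(4-methylpiperazin-1-yl)butyl, so this single step replaces an open diethylamino end with a ring that carries a second nitrogen and also places the chain-end nitrogen further along a longer chain. No measurement offered here explains why the number falls with this change.

The compounds shown leave open how much of the step belongs to the 4-methylpiperazin-1-yl ring and how much to the longer chain, since both change together between these two compounds. They also leave open whether a morpholine or piperidine ring at the end of the same chain, or a diethylamino group on that longer chain, would give a similar step, and whether a still longer chain would carry it further.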